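This account rests on a few compounds, and the source may have more. Where it says the series, first, only, none or still open, it means among the compounds named here.

Compound 3 `c1ccc(-c2ccc(Cn3cncc3CNc3ccc(-c4cc5ccccc5o4)c(-c4ccccc4)c3)cc2)cc1` carries a 1-benzofuran-2-yl group where compound 2 `c1ccc(-c2ccc(Cn3cncc3CNc3ccc(N4CCCCC4)c(-c4ccccc4)c3)cc2)cc1` carries piperidin-1-yl. In a toxicity assay on NIH3T3 cells (Mus musculus) for cytotoxicity, read by resazurin assay (on this read-out higher numbers stand for an effect only at larger amounts of compound and lower numbers for an effect already at smaller amounts), compound 3 gives only a limit, > 10000 nM, and not a number. In this assay compound 2 likewise gives only a limit, > 1000 nM. The step from compound 2 to compound 3 is therefore a step that the two limits leave unreadable from compound 2 to compound 3, since both values sit at limits, one at the limit of > 1000 nM in this assay, at which 1 of the 3 values shown sits, and the other at the limit of > 10000 nM in this assay, at which 1 of the 3 values shown sits. Compound 1 `COC(=O)c1ccc(NCc2cncn2Cc2ccccc2Cl)cc1-c1ccccc1`, which bears a methoxycarbonyl group in a comparable position, gives 10000 nM in this assay.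

Compound 4 `CCOC(=O)c1ccc(NCc2cncn2Cc2ccc(-c3ccccc3)cc2)cc1-c1ccccc1` differs from compound 3 by ethoxycarbonyl in place of 1-benzofuran-2-yl on an aromatic carbon. Within the data shown here, no measured step bears directly on this change, and the single readable value in this assay, that of compound 1, sits at the top of the measured range. Compound 4 is therefore expected to show a step of a number no higher from compound 3 to compound 4 (the limit leaves the size open), which is to say no readable change. The estimate for compound 4 in this assay is 10000 nM, with a range from 3000 nM to 30000 nM, and a reported limit rather than a number is considered likely.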

Compound 4, half-maximal effective concentration: > 10000 nM
Compound 4 was reported as a limit (the forecaster's own chance of this, stated with the estimate: 55%); the middle value sits exactly at the limit.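

In this assay compound 2, compound 3 and compound 4 each give only a limit and not a number, and no step among these three compounds can be read. The compounds shown leave open whether exchanging these groups on the aromatic carbon changes the read-out at all.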